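This account rests on a few compounds, and the source may have more. Where it says the series, first, only, none or still open, it means among the compounds named here.

Measured so far:
Compound 1, `CCCCCCCCCCCCCCCCCCNC(=O)[C@H]1CSC(c2ccc(F)cc2)N1`: 6800 nM
Compound 2, `CCCCCCCCCCCCCCCCCCNC(=O)[C@H]1CSC(c2ccc(Br)cc2)N1`: 17300 nM

Both compounds share the same core and differ only in the aromatic ring attached to the saturated ring carbon. In a functional assay on PC-3 cells (Homo sapiens) for antiproliferative activity, read by sulforhodamine B assay (a higher number here means a weaker inhibitor, a lower number a stronger inhibitor), compound 1 gives 6800 nM, while compound 2 gives 17300 nM. Among the measured compounds shown here, compound 2 therefore stands at the higher of the two numbers, making it the weaker of the pair; the single measured step, a 2.5-fold higher number from compound 1 to compound 2 (0.41 log units; beyond the scatter), is modest but lies beyond the scatter.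

Compound 3, `CCCCCCCCCCCCCCCCCCNC(=O)[C@H]1CSC(c2cc(F)cc(F)c2)N1`, differs from compound 2 by 3,5-difluorophenyl in place of 4-bromophenyl on a saturated ring carbon. For the measured compounds named here, the only step that bears on this change is the one from compound 1 to compound 2, which shows that swapping fluorine for bromine on the aromatic ring raised the number. Going by the values given here, compound 3 brings fluorine back, but as a 3,5-difluorophenyl rather than the 4-fluorophenyl of compound 1, an arrangement no measured compound covers. A return toward the number of compound 1 seems the most reasonable expectation, with added uncertainty. Compound 3 is thus expected to give 9000 nM, with a range from 3500 nM to 25000 nM. The expected step of a 1.9-fold lower number from compound 2 to compound 3 (0.28 log units; within the scatter) is a modest move toward a lower number.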

Compound 3, half-maximal inhibitory concentration: > 20000 nM
Compound 3 gave a limit, no number; the forecaster's own chance of this, stated with the estimate: 10%; middle value at least 2.2-fold (0.34 log units) away from the limit.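

In this assay compound 3 gave a limit and not a number: the limit of > 20000 nM in this assay, at which 1 of the 3 values shown sits. Fluorine on the aromatic ring does not by itself secure the level of compound 1, as replacing 4-fluorophenyl with 3,5-difluorophenyl on this saturated ring carbon gives an at least 2.9-fold higher number from compound 1 to compound 3 (0.46 log units; beyond the scatter), so the two fluorine-bearing compounds do not behave alike at this position. The comparison with 4-bromophenyl says much less, with an at least 1.1-fold higher number from compound 2 to compound 3 (0.06 log units; that floor lies within the scatter), so compound 3 cannot be put in order with compound 2, and the real gap between them may be small or large.

Going by these compounds, how much weaker compound 3 really is stays unknown, and these three compounds cannot separate the effect of having two fluorines from the effect of where those fluorines sit on the aromatic ring. Also open, on these data alone, is whether an amine or a methoxy group on that ring, or a shorter chain in place of the octadecyl chain on the amide, would give a lower number than compound 1 does in this assay.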